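From Phenylsulfanyl to Benzoyl: Expecting a Stronger Effect

A few compounds are considered here, and "the series" means these few. Any claim that something is new, unique, unknown or untested is made for them only; others in the source may bear on it.

Compound 1, `COC(=O)Nc1nc2cc(Oc3cccc(N4CCN(C)CC4)n3)ccc2[nH]1`: 52.1%
Compound 2, `O=C(Nc1nc2cc(Sc3ccccc3)ccc2[nH]1)OC1COC1`: 87.8%
Compound 3, `COC(=O)Nc1nc2cc(C(=O)c3ccc(N(C)C4COC4)cc3)ccc2[nH]1`: 33.6%

These three compounds share a common core and were tested in a functional assay on PC-3 cells (Homo sapiens) for cytotoxicity, read by MTT assay, with a stated time of 72 h, tested at 10 uM; a lower number here means a stronger effect, a higher number a weaker effect of the compound at the concentration tested. Among them compound 2 shows the weakest effect: its number is the highest, and its gaps to compound 1 and to compound 3 both lie beyond the usual scatter. Compound 4, `O=C(Nc1nc2cc(C(=O)c3ccccc3)ccc2[nH]1)OC1COC1`, has not yet been measured. It differs from compound 2 in one place: benzoyl in place of phenylsulfanyl on an aromatic carbon. Among the compounds with values here, no pair of measured compounds covers exactly this change, so any expectation rests on a loose comparison. Compound 3, whose structure also carries a benzoyl linkage to the core, though with a further substituted ring, gives 33.6%, a clearly stronger effect than compound 2. A moderate downward step is therefore expected, a number 27.8 percentage points lower from compound 2 to compound 4 (beyond the scatter), with wide uncertainty. Compound 4 is estimated at 60%, somewhere between 35% and 88%.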

Compound 4, a percentage reported as activity, at one concentration (the size of the read-out at that concentration, not a potency): 65.6%
Compound 4: the middle estimate sits 5.6 percentage points below what was measured; the range from low to high includes it.
By their numbers in this assay, from the lowest: compound 3; then compound 1; then compound 4; then compound 2.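

In this assay, exchanging phenylsulfanyl for benzoyl on this aromatic carbon gives a number 22.2 percentage points lower from compound 2 to compound 4 (beyond the scatter). Within the data shown here, this is the first direct pair at this position, and it shows that the read-out responds to the link to the core, sulfur or carbonyl, even though both groups carry the same kind of aromatic ring. No measured evidence here explains the step.

As far as these compounds go, whether a sulfonyl or methylene link at the same place would read closer to compound 2 or to compound 4 remains open. So does the effect of adding a carboxylic acid to the outer ring of compound 4.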